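Lengthening the hydroxymethyl chain in an inactive lactone series

The source may report more compounds than this note shows. Statements on the series, on what has been measured and on what is new or still open speak of the compounds shown alone.

Compound 1, `O=c1oc(CO)cc2ccccc12`, gives >= 250 ug/mL in a functional assay on NCI/ADR-RES cells (Homo sapiens) for antiproliferative activity, read by sulforhodamine B assay, with a stated time of 48 h (a lower number here means a stronger inhibitor of growth, a higher number a weaker inhibitor of growth), which is a limit of the assay and not a number.
Compound 2, `O=C1OC(CO)Cc2ccccc21`, gives >= 250 ug/mL in this assay, again a limit of the assay.
Compound 3, `COc1ccc2c(c1)C(=O)OC(CO)C2`, gives >= 250 ug/mL in this assay, also a limit of the assay.

Compound 3 therefore stands at the limit together with the two other measured compounds, and nothing separates it from them on the numbers shown. Within the data shown here, the only step between measured compounds, a step that the two limits leave unreadable from compound 2 to compound 3, cannot be read, because of the limit of >= 250 ug/mL in this assay, at which 3 of the 3 values shown sit.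

Compound 4, `COc1ccc2c(c1)C(=O)OC(CCCO)C2`, differs from compound 3 by 2-hydroxyethyl in place of hydroxy on a saturated chain carbon bound to a saturated ring carbon. Among the measured compounds shown here, no measured step bears on this change, and the one step recorded is itself unreadable, so no direction or size can be taken from it. Since every measured compound sits at the limit, compound 4 is expected to show no step beyond the scatter, that is a number no higher from compound 3 to compound 4 (the limit leaves the size open). The estimate for compound 4 in this assay is accordingly 250 ug/mL, with a range from 100 ug/mL to 500 ug/mL, most likely reported again as a limit.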

Compound 4, concentration for 50% growth inhibition: 93.3 ug/mL
Compound 4: the middle estimate sits 2.7-fold (0.43 log units) above what was measured; the whole stated range lies above it.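

In this assay, among these compounds, the change from hydroxymethyl to 3-hydroxypropyl gives an at least 2.6-fold lower number from compound 3 to compound 4 (0.42 log units; beyond the scatter), the first step that can be read. Among the compounds shown here, a change on a saturated chain carbon bound to a saturated ring carbon can therefore bring a compound off the limit, which the earlier compounds did not show. The size of this step has only a lower bound, because compound 3 sits at a limit of the assay and not at a number: the limit of >= 250 ug/mL in this assay, at which 3 of the 4 values shown sit.

As far as these compounds go, it remains open whether a still longer chain would lower the number further, or whether an amine or a carboxylic acid could stand in place of the terminal hydroxy. Also open, from the compounds shown here alone, is whether 3-hydroxypropyl would give a similar result on the core of compound 2, which lacks the methoxy.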